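The source may hold more compounds than are shown below. What is called first, only, known or untested is meant among the compounds shown, and "the series" means these compounds.

Of the compounds shown here, two sharing one core have been read in an ADME assay on L02 cells (Homo sapiens) for cytotoxicity, read by MTT assay, with a stated time of 24 h; on this read-out higher numbers stand for weaker inhibition and lower numbers for stronger inhibition. In that assay, compound 1 `O=C1/C(=C/c2cccnc2)CN(S(=O)(=O)c2ccccc2)C/C1=C\c1ccccc1F` gives 15300 nM, and compound 2 `O=C1/C(=C/c2cccnc2)CN(S(=O)(=O)c2ccc(C(F)(F)F)cc2)C/C1=C\c1ccccc1F` gives 11300 nM. For the measured compounds named here, compound 2 therefore cannot be told apart from compound 1, the only other compound with a number so far. Compound 3 `O=C1/C(=C/c2cccnc2)CN(S(=O)(=O)c2ccc(F)cc2)C/C1=C\c1ccccc1F` has not yet been measured. It departs from compound 2 in one place, fluoro in place of trifluoromethyl on an aromatic carbon, para to a large group. Going by the values given here, only one measured step bears on this change, the exchange of hydrogen for trifluoromethyl at that same place, and it was small: a 1.4-fold lower number from compound 1 to compound 2 (0.13 log units; within the scatter). Because of a 1.4-fold lower number from compound 1 to compound 2 (0.13 log units; within the scatter) no shift beyond the scatter is expected in this assay from the exchange of trifluoromethyl for fluoro, and no direction can be firmly assigned. The estimated change is only a 1.2-fold higher number from compound 2 to compound 3 (0.06 log units; within the scatter), which would remain within the scatter. Compound 3 is expected to read about 13000 nM, with an estimated range of 7000 nM to 24000 nM.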

Compound 3, half-maximal inhibitory concentration: 15600 nM
Compound 3: the middle estimate sits 1.2-fold (0.08 log units) below what was measured, and the stated range covers the measured number.
By their numbers in this assay, from the lowest: compounds 2, 1 and 3 (each within the scatter of the next).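

With fluoro now read at the aromatic carbon para to a large group, this place has carried hydrogen, fluoro and trifluoromethyl, and in this assay neither new exchange leaves the scatter: the change from 4-(trifluoromethyl)phenyl to 4-fluorophenyl gives a 1.4-fold higher number from compound 2 to compound 3 (0.14 log units; within the scatter), and fluoro in place of hydrogen gives a 1.0-fold higher number from compound 1 to compound 3 (0.01 log units; within the scatter). The earlier pair had shown this for trifluoromethyl and hydrogen alone, whereas the three compounds together show that neither the small fluoro nor the larger trifluoromethyl can be told apart from hydrogen here, so that this read-out does not separate any of the three substituents at this place. Nothing available offers an explanation for this flat reading.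

Going by these compounds, all three substituents are halogen-bearing groups or hydrogen, so it remains open whether the reading would stay this flat with an amine, a carboxylic acid or a longer chain at the same carbon. On these data alone, it is also open whether these exchanges would leave the number equally unmoved on a core carrying different groups at its other places.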